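A few compounds are considered here, and "the series" means these few. Any claim that something is new, unique, unknown or untested is made for them only; others in the source may bear on it.

Compound 1 `O=C(CCCCC#Cc1cccc(Cl)c1Cl)c1ncc(-c2ccccn2)o1`: 5 nM in an assay for inhibition of Fatty-acid amide hydrolase 1 (Rattus norvegicus); on this read-out higher numbers stand for weaker inhibition and lower numbers for stronger inhibition.
Compound 2 `O=C(CCCCC#Cc1ccncc1)c1ncc(-c2ccccn2)o1`: 150 nM in this assay.
Compound 3 `O=C(CCCCC#Cc1ccc([N+](=O)[O-])cc1)c1ncc(-c2ccccn2)o1`: 31 nM in this assay.

Compound 2 stands highest of the three in this assay, with a 4.8-fold lower number from compound 2 to compound 3 (0.68 log units; beyond the scatter) and a 30-fold higher number from compound 1 to compound 2 (1.48 log units; beyond the scatter) marking its distance from the others. Compound 4 `O=C(CCCCSCc1ccccc1)c1ncc(-c2ccccn2)o1` carries benzylsulfanyl in place of 2-(pyridin-4-yl)ethynyl on a saturated chain carbon, four bonds along the chain from a carbonyl carbon. Going by the values given here, no measured step matches this change, but both steps that exchange the pyridin-4-yl group on the triple-bonded carbon for a carbon-only ring, a 30-fold higher number from compound 1 to compound 2 (1.48 log units; beyond the scatter) and a 4.8-fold lower number from compound 2 to compound 3 (0.68 log units; beyond the scatter), lowered the number by modest to large amounts. Since compound 4 also trades the triple bond for a saturated link, a more cautious, modest step downward is expected in this assay. Compound 4 is therefore estimated at 40 nM, between 10 nM and 160 nM, which means an expected step of a 3.8-fold lower number from compound 2 to compound 4 (0.57 log units; beyond the scatter).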

Compound 4, inhibition constant: 25 nM
Compound 4: middle estimate off by 1.6-fold (0.20 log units), on the high side; the measured number falls inside the stated range.
By their numbers in this assay, from the lowest: compound 1; then compounds 4 and 3 (each within the scatter of the next); then compound 2.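

At this place on the chain, the triple bond is not needed for inhibition in this assay: benzylsulfanyl on the saturated chain gives a 6.0-fold lower number from compound 2 to compound 4 (0.78 log units; beyond the scatter). The earlier compounds shown here changed only the ring on the triple-bonded carbon, whereas this step replaces the link and the ring together. Nothing shown here explains the step.

The two changes therefore remain unseparated: how much of the step belongs to the sulfur-containing link and how much to the carbon-only ring is open. A pyridin-4-ylmethylsulfanyl or benzyloxy group at this place could divide them.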